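Methoxy for methyl in the shared core series

The source may report more compounds than this note shows. Statements on the series, on what has been measured and on what is new or still open speak of the compounds shown alone.

Compound 1 `Cc1ccc(-c2cn(-c3ccc(CN4CCCCC4)cc3)nn2)cc1Nc1nccc(-c2cccnc2)n1` gives 740 nM in a functional assay on HL-60 cells (Homo sapiens) for inhibition, read by MTT assay, with a stated time of 72 h; on this read-out lower numbers stand for stronger inhibition and higher numbers for weaker inhibition. Compound 2 `Cc1ccc(-n2cc(-c3ccc(CN4CCN(C)CC4)c(C(F)(F)F)c3)nn2)cc1Nc1nccc(-c2cccnc2)n1` gives 20 nM in this assay. For compound 3 `Cc1ccc(-n2cc(-c3ccc(C)c(C(F)(F)F)c3)nn2)cc1Nc1nccc(-c2cccnc2)n1` this assay returns only a limit, > 30000 nM, and not a number.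

Compound 3 thus stands at the weak end of the three shown values; it is the one compound sitting at the limit of > 30000 nM in this assay, at which 1 of the 3 values shown sits, so its true value is not known beyond that boundary.

Compound 4 `COc1ccc(-c2cn(-c3ccc(C)c(Nc4nccc(-c5cccnc5)n4)c3)nn2)cc1C(F)(F)F` differs from compound 3 by methoxy in place of methyl on an aromatic carbon.

Within the data shown here, the one measured step in the set, an at least 1500-fold higher number from compound 2 to compound 3 (3.17 log units; beyond the scatter), concerns a change at a different place, the saturated chain carbon on the other aryl group, and says nothing about a methyl-to-methoxy exchange on the aromatic carbon. Among the measured compounds shown here, compound 1 and compound 2 carry other groups at that position, so no measured pair isolates this change either. With nothing in the data bearing on it, the expectation is no movement beyond the scatter, a number no higher from compound 3 to compound 4 (the limit leaves the size open).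

Compound 4 is therefore estimated at 30000 nM, with a range from 10000 nM to 90000 nM, and a good chance that this assay again reports only a limit.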

Compound 4, half-maximal inhibitory concentration: 21200 nM
The estimate for compound 4 lay 1.4-fold (0.15 log units) above the measured number, and the stated range covers the measured number.
By their numbers in this assay, from the lowest: compound 2; then compound 1; then compound 4. At a limit, above all of these: compound 3.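

Moving from 4-methyl-3-(trifluoromethyl)phenyl to 4-methoxy-3-(trifluoromethyl)phenyl gives a true number in this assay for an aryl group that lacks the (4-methylpiperazin-1-yl)methyl group: compound 4 gives 21200 nM. Compound 3 remains a limit and not a number: the limit of > 30000 nM in this assay, at which 1 of the 4 values shown sits. The exchange of methyl for methoxy therefore reads only as an at least 1.4-fold lower number from compound 3 to compound 4 (0.15 log units; that floor lies within the scatter), while methoxy does not stand in for (4-methylpiperazin-1-yl)methyl at this position, the step being a 1100-fold higher number from compound 2 to compound 4 (3.03 log units; beyond the scatter).

As far as these compounds go, the true size of the methyl-to-methoxy step stays open, and with only a floor to go on, these compounds cannot tell whether the exchange moves the number beyond the scatter at all. Also open, from the compounds shown here alone, is how much of the strength seen with (4-methylpiperazin-1-yl)methyl would survive at this aromatic carbon with a simpler amine such as dimethylaminomethyl, with a morpholine on the same carbon link, or with a longer chain carrying the piperazine further from the ring.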